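Two Weak Antiproliferative Lactams and a Reworked Aryl Group

The source may hold more compounds than are shown below. What is called first, only, known or untested is meant among the compounds shown, and "the series" means these compounds.

Compound 1, `COc1cc(N2C(=O)[C@@H](Oc3ccccc3)[C@H]2c2cccc3ccccc23)cc(OC)c1OC`, was tested in a functional assay on MCF7 cells (Homo sapiens) for antiproliferative activity, read by MTT assay, with stated times of 24 h and 72 h; on this read-out lower numbers stand for stronger inhibition and higher numbers for weaker inhibition. In this assay compound 1 gives 53000 nM. Going by the values given here, only one other compound was measured alongside it: compound 2, `COc1ccc(N2C(=O)[C@@H](Oc3ccccc3)[C@H]2c2ccc(OC)c(O)c2)cc1`, which in this assay gives 49000 nM. The two numbers lie within the usual scatter of repeated measurements of each other, so neither compound can be set apart from the other on these data; both sit in the weak range of the read-out.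

Compound 3, `COc1cc(N2C(=O)[C@@H](Oc3ccccc3)[C@H]2c2cc(N)c(OC)c(O)c2)cc(OC)c1OC`, has not yet been measured. It keeps the shared core of compound 1 and changes one group on it: a group of 10 heavy atoms (7 carbon, 1 nitrogen, 2 oxygen; one six-membered aromatic ring of carbon only) in place of a group of 10 heavy atoms (10 carbon; 2 six-membered aromatic rings of carbon only), on a saturated ring carbon.

Among the compounds with values here, no measured pair in this set differs in a single place, so there is no step from which to read how such a change moves the number. The expectation rests only on the two measured values. Because compound 1 gives 53000 nM and compound 2 gives 49000 nM, the number for compound 3 is expected to stay in the same weak region. The step from compound 1 to compound 3 is estimated as a 1.3-fold lower number from compound 1 to compound 3 (0.12 log units; within the scatter), with no change beyond the scatter foreseen. Compound 3 is thus estimated at 40000 nM, within a range from 10000 nM to 150000 nM.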

Compound 3, half-maximal inhibitory concentration: 8800 nM
Estimate against measurement, compound 3: 4.5-fold (0.66 log units) above; the whole stated range lies above it.
By their numbers in this assay, from the lowest: compound 3; then compounds 2 and 1 (each within the scatter of the next).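

In this assay, going by these compounds alone, putting the new single-ring group in place of the naphthalen-1-yl group on the saturated ring carbon gives a 6.0-fold lower number from compound 1 to compound 3 (0.78 log units; beyond the scatter), the first step in this set that lies beyond the scatter. This shows that what sits at this place on the four-membered ring can move the number, even though the entering and leaving groups have the same count of heavy atoms; the two differ instead in having one aromatic ring or two, and in the entering group carrying hydrogen-bond donors and acceptors where the naphthalen-1-yl group has none. No measurement shown here explains why the number moves with this change.

This single step replaces the whole group at once, so it cannot tell which part of the entering group goes with the lower number, or whether the ring count or the donors and acceptors matter at all. Also open, from the compounds shown here alone, is how a plain phenyl group at this place would compare, and whether a carboxylic acid or a longer chain on the single ring would keep the lower number or lose it.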